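Longer Acyl Chains on a Shared Core: Cell Growth Inhibition

The compounds below may be only part of what the source reports. "The series", "measured", "known", "first", "only" and "open" are said of these compounds alone.

In a functional assay on MCF7 cells (Homo sapiens) for inhibition, read by MTT assay, with a stated time of 72 h (on this read-out higher numbers stand for weaker inhibition and lower numbers for stronger inhibition), three compounds have been measured so far:

compound 1 `CC(=O)N1CCN(c2nnc3nncn3n2)CC1` gives 13900 nM
compound 2 `CCC(=O)N1CCN(c2nnc3nncn3n2)CC1` gives 14800 nM
compound 3 `CCCCC(=O)N1CCN(c2nnc3nncn3n2)CC1` gives 2760 nM

Compound 2 differs from compound 1 by methyl in place of hydrogen on a saturated chain carbon bound to a carbonyl carbon, and in this assay this gives a 1.1-fold higher number from compound 1 to compound 2 (0.03 log units; within the scatter). Compound 3 differs from compound 1 by propyl in place of hydrogen on a saturated chain carbon bound to a carbonyl carbon, which gives a 5.0-fold lower number from compound 1 to compound 3 (0.70 log units; beyond the scatter), and against compound 2 it gives a 5.4-fold lower number from compound 2 to compound 3 (0.73 log units; beyond the scatter). Compound 4 `CCCCCC(=O)N1CCN(c2nnc3nncn3n2)CC1` has not yet been measured; it differs from compound 3 by methyl in place of hydrogen on a saturated chain carbon, four bonds along the chain from a carbonyl carbon. For the measured compounds named here, this is the same kind of change as the one from compound 1 to compound 2, but the place differs: there the methyl enters on a saturated chain carbon bound to a carbonyl carbon, here on a saturated chain carbon four bonds along the chain from a carbonyl carbon. Because the earlier step of a 1.1-fold higher number from compound 1 to compound 2 (0.03 log units; within the scatter) lay within the scatter while only the longer chain of compound 3 brought a clear gain, the step from compound 3 to compound 4 is expected to be small, about a 1.4-fold lower number from compound 3 to compound 4 (0.14 log units; within the scatter). Compound 4 is therefore estimated at 2000 nM, between 700 nM and 6000 nM.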

Compound 4, half-maximal inhibitory concentration: 5260 nM
Compound 4: middle estimate off by 2.6-fold (0.42 log units), on the low side; the measured number falls inside the stated range.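

In this assay, methyl in place of hydrogen gives a 1.9-fold higher number from compound 3 to compound 4 (0.28 log units; within the scatter), and this small step carries over from the shorter chain without a difference that can be told apart: the same change on two cores in this assay, a 1.1-fold higher number (0.03 log units; within the scatter) from compound 1 to compound 2 and a 1.9-fold higher number (0.28 log units; within the scatter) from compound 3 to compound 4, 1.8-fold (0.25 log units) apart, within the scatter of two such steps

Propyl in place of hydrogen, on a saturated chain carbon two bonds along the chain from a carbonyl carbon, gives a 2.8-fold lower number from compound 2 to compound 4 (0.45 log units; beyond the scatter), and this clear step also agrees with its earlier counterpart on the other chain: the same change on two cores in this assay, a 5.0-fold lower number (0.70 log units; beyond the scatter) from compound 1 to compound 3 and a 2.8-fold lower number (0.45 log units; beyond the scatter) from compound 2 to compound 4, 1.8-fold (0.25 log units) apart, within the scatter of two such steps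

For the compounds shown here, the largest change of the chain in this set gives a 2.6-fold lower number from compound 1 to compound 4 (0.42 log units; beyond the scatter), but each comparison rests on only two steps on the shared core, so none of this shows that the changes would carry over to a different core.

On these data alone, it remains open whether a longer chain would keep the numbers near those of compound 3 and compound 4. As far as these compounds go, it also remains open how an amine or a carboxylic acid in place of the acyl chain would read out.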